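From 2-chlorobenzyl to 3-chlorobenzyl in an antiproliferative series

The compounds below may be only part of what the source reports. "The series", "measured", "known", "first", "only" and "open" are said of these compounds alone.

Values in a functional assay on HeLa cells (Homo sapiens) for antiproliferative activity, read by MTT assay, with a stated time of 24 h; on this read-out higher numbers stand for weaker inhibition and lower numbers for stronger inhibition:
- compound 1 `Sc1nnc(-c2ccc3c(c2)OCCO3)n1-c1ccccc1` gives 51900 nM
- compound 2 `O=[N+]([O-])c1ccc(CSc2nnc(-c3ccc4c(c3)OCCO4)n2-c2ccccc2)cc1` gives 36200 nM
- compound 3 `Clc1ccccc1CSc1nnc(-c2ccc3c(c2)OCCO3)n1-c1ccccc1` gives 29000 nM

All three values lie within the scatter of one another, so compound 3 does not stand apart from the other two. Compound 4 `Clc1cccc(CSc2nnc(-c3ccc4c(c3)OCCO4)n2-c2ccccc2)c1` brings a further change: 3-chlorophenyl in place of 2-chlorophenyl on a saturated chain carbon bound to a sulfur. Among the measured compounds shown here, no measured step covers this exact swap. The nearest is a 1.2-fold lower number from compound 2 to compound 3 (0.10 log units; within the scatter), at the same place. Replacing hydrogen on a sulfur gave a 1.4-fold lower number from compound 1 to compound 2 (0.16 log units; within the scatter) and a 1.8-fold lower number from compound 1 to compound 3 (0.25 log units; within the scatter). None exceeds the scatter, so no step beyond it is expected in this assay. The estimated step is a 1.0-fold higher number from compound 3 to compound 4 (0.01 log units; within the scatter) and rests on compound 3 at 29000 nM as its starting point. Compound 4 is estimated at 30000 nM, with an expected range from 15000 nM to 60000 nM for its measurement.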

Compound 4, half-maximal inhibitory concentration: 15000 nM
Estimate against measurement, compound 4: 2.0-fold (0.30 log units) above; measured number inside the range.
By their numbers in this assay, from the lowest: compounds 4, 3, 2 and 1 (each within the scatter of the next, the first and the last beyond it).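

In this assay, 3-chlorobenzyl in place of 2-chlorobenzyl gives a 1.9-fold lower number from compound 3 to compound 4 (0.29 log units; within the scatter) and so leaves these two compounds indistinguishable. Even so, compound 4 alone stands beyond the scatter from any other compound shown. Its modest separations are a 2.4-fold lower number from compound 2 to compound 4 (0.38 log units; beyond the scatter) with 3-chlorophenyl in place of 4-nitrophenyl and a 3.5-fold lower number from compound 1 to compound 4 (0.54 log units; beyond the scatter) with 3-chlorobenzyl in place of hydrogen on the sulfur. Nothing available explains these differences. The compounds shown leave open how a plain benzyl or a 3-aminobenzyl on the sulfur would compare with compound 4.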